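Two hydroxyls on the aryl ring: a forecast

The source may hold more compounds than are shown below. What is called first, only, known or untested is meant among the compounds shown, and "the series" means these compounds.

Measured compounds:
compound 1 `O=C(CSc1nnc(-c2ccncc2)o1)N/N=C/c1ccc(F)cc1`: 15700 nM
compound 2 `O=C(CSc1nnc(-c2ccncc2)o1)N/N=C/c1ccccc1O`: 7380 nM

In a functional assay on SW 1116 cells (Homo sapiens) for cytotoxicity, read by MTT assay, with a stated time of 48 h (a higher number here means a weaker inhibitor, a lower number a stronger inhibitor), compound 1 gives 15700 nM and compound 2 gives 7380 nM, so compound 2 stands lowest of the two numbers. Among the compounds with values here, the only known step is a 2.1-fold lower number from compound 1 to compound 2 (0.33 log units; beyond the scatter). Compound 3 `O=C(CSc1nnc(-c2ccncc2)o1)N/N=C/c1ccc(O)c(O)c1` differs from compound 2 by 3,4-dihydroxyphenyl in place of 2-hydroxyphenyl on a carbon with a double bond to nitrogen. Within the data shown here, because the step of a 2.1-fold lower number from compound 1 to compound 2 (0.33 log units; beyond the scatter) was modest and no step concerns a second hydroxyl, the expected step in this assay is a 1.2-fold lower number from compound 2 to compound 3 (0.09 log units; within the scatter), small and within the scatter. Compound 3 is therefore estimated at 6000 nM, with a range from 2500 nM to 15000 nM.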

Compound 3, half-maximal inhibitory concentration: 1540 nM
Compound 3: the middle estimate sits 3.9-fold (0.59 log units) above what was measured, outside the stated range (below it).
By their numbers in this assay, from the lowest: compound 3; then compound 2; then compound 1.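

In this assay the aryl group on a carbon with a double bond to nitrogen turns out to have more range than the first pair showed: 3,4-dihydroxyphenyl gives a 4.8-fold lower number from compound 2 to compound 3 (0.68 log units; beyond the scatter), and against 4-fluorophenyl it gives a 10-fold lower number from compound 1 to compound 3 (1.01 log units; beyond the scatter). This change alters both the number of hydroxyls and where they stand, so the step does not separate the two. No evidence on the reason for the lower number accompanies these compounds. From the compounds shown here alone, whether a single hydroxyl in 4-hydroxyphenyl, or a methoxy group in place of either hydroxyl, would keep the number this low remains open.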